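Testing a shorter, fluorinated side chain on compound 1

The source may report more compounds than this note shows. Statements on the series, on what has been measured and on what is new or still open speak of the compounds shown alone.

Compound 1, `Cc1nn(-c2ncnc3nc[nH]c23)c2c1C(OCCc1ccccc1)CC(=O)N2`, gives 3 nM in a functional assay on HEK293 cells for agonist activity at G-protein coupled receptor 39 (Homo sapiens), read by scintillation proximity assay and inositol phosphate accumulation, with a stated time of 75 min, in the presence of a further agent that is not named here; a lower number here means that less compound is needed, a higher number that more compound is needed for the effect.
Compound 2, `O=C1/C(=C/NCCCO)C(c2ccccc2)=NN1c1nc2ccccc2s1`, gives 200 nM.
Compound 3, `Cc1nn(-c2ncnc3nc[nH]c23)c2c1C(C(=O)NCc1ccc(F)cc1)CC(=O)N2`, gives 4 nM.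

Compound 1 has the lowest number of the three. Its gap to compound 3 lies within the scatter of the assay, so the two cannot be told apart; compound 2, built on a different core, needs a far higher concentration, and that gap lies beyond the scatter. The unmeasured compound 4, `Cc1nn(-c2ncnc3nc[nH]c23)c2c1C(OCc1ccccc1F)CC(=O)N2`, keeps the core of compound 1 and changes only the side chain: 2-fluorophenyl in place of benzyl on a saturated chain carbon bound to an oxygen on a saturated carbon. Among the compounds with values here, no measured pair shows this exact change, so the step is expected to be small, in either direction or none beyond the scatter. Compound 4 is therefore estimated at 6 nM, within 1.5 nM to 25 nM, a step of a 2.0-fold higher number from compound 1 to compound 4 (0.30 log units; within the scatter).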

Compound 4, half-maximal effective concentration: 4 nM
Estimate against measurement, compound 4: 1.5-fold (0.18 log units) above, and the stated range covers the measured number.
By their numbers in this assay, from the lowest: compounds 1, 3 and 4 (each within the scatter of the next); then compound 2.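

In this assay, within the data shown here, the exchange of benzyl for 2-fluorophenyl on a saturated chain carbon bound to an oxygen on a saturated carbon gives a 1.3-fold higher number from compound 1 to compound 4 (0.12 log units; within the scatter) and is the first comparison here that differs in one place. At this position, then, phenethyl and 2-fluorobenzyl cannot be told apart. Nothing available here gives a reason for this result.

The step changes the chain and adds fluorine together, and the compounds shown do not separate these two parts. On these data alone, it also remains open how this position would respond to an amine or a carboxylic acid at the end of the chain.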